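This account rests on a few compounds, and the source may have more. Where it says the series, first, only, none or still open, it means among the compounds named here.

Measured compounds:
- compound 1, `CC(C)(C)OC(=O)NCCS(=O)(=O)NC(=O)c1ccc(Nc2nc(NC3(c4ccc(Cl)cc4)CC3)nc(OCC(F)(F)F)n2)cc1`: 93%
- compound 2, `CC(C)C(=O)NCCS(=O)(=O)NC(=O)c1ccc(Nc2nc(NC3(c4ccc(Cl)cc4)CC3)nc(OCC(F)(F)F)n2)cc1`: 84%

In an ADME assay on microsomes from liver (Rattus norvegicus) for metabolic stability, with a stated time of 10 min (a higher number here means that more of the compound is left, a lower number that less of the compound is left), compound 1 gives 93%, and compound 2 gives 84%. Among the compounds with values here, the only measured step, a number 9 percentage points lower from compound 1 to compound 2 (within the scatter), exchanges a group on a carbonyl carbon. Compound 2 thus has the lowest of the two numbers, but its gap to compound 1 lies within the scatter, so the two are not told apart by this assay.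

Compound 3, `O=C(NS(=O)(=O)c1ccccc1)c1ccc(Nc2nc(NC3(c4ccc(Cl)cc4)CC3)nc(OCC(F)(F)F)n2)cc1`, differs from compound 2 by phenyl in place of 2-((isopropylcarbonyl)amino)ethyl on a sulfonyl sulfur. Within the data shown here, the measured step of a number 9 percentage points lower from compound 1 to compound 2 (within the scatter) touches a different part of the molecule and was within the scatter, so it gives only a loose guide here; no measured step exchanges a chain for a ring at the sulfonyl sulfur. The expected step of a number 4 percentage points lower from compound 2 to compound 3 (within the scatter) is therefore small, with no clear direction beyond the scatter. Compound 3 is estimated at 80%, in a range from 60% to 95%.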

Compound 3, percent of the compound remaining: 100%
For compound 3 the middle estimate is 20 percentage points below the measured one; the whole stated range lies below it.
By their numbers in this assay, from the lowest: compounds 2, 1 and 3 (each within the scatter of the next, the first and the last beyond it).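

In this assay the swap of 2-((isopropylcarbonyl)amino)ethyl for phenyl on the sulfonyl sulfur gives a number 16 percentage points higher from compound 2 to compound 3 (beyond the scatter) and so is the only step shown whose size lies beyond the scatter. Made against the 2-((tert-butoxycarbonyl)amino)ethyl chain, the same kind of swap gives a number 7 percentage points higher from compound 1 to compound 3 (within the scatter) and does not separate those two compounds. This position therefore accepts an aromatic ring with no hydrogen-bond donor or acceptor in place of either chain, without any loss in the amount of compound left, and the size of the change depends on which chain leaves.

Nothing shown gives a reason for the modest step from the isopropyl chain to phenyl. Also open, going by these compounds, is how a chlorophenyl ring, a pyridine ring, a simple methyl group or a chain ending in a carboxylic acid would fare at this sulfonyl sulfur.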